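Removing One Methyl From Compound 3

This account rests on a few compounds, and the source may have more. Where it says the series, first, only, none or still open, it means among the compounds named here.

Compound 1 `CC1OC2(C=CC(=O)C=C2)N(c2nc(-c3cccc4ccccc34)nn2-c2ccccc2)C1=O` gives 100 nM
Compound 2 `O=C1C=CC2(C=C1)OCC(=O)N2c1nc(-c2ccc3c(c2)OCCO3)nn1-c1ccccc1` gives 100 nM
Compound 3 `Cc1ccc(-n2nc(-c3cccc4ccccc34)nc2N2C(=O)COC23C=CC(=O)C=C3)cc1` gives 40 nM

In a functional assay on MDA-MB-231 cells (Homo sapiens) for antiproliferative activity, with a stated time of 5 days (a higher number here means a weaker inhibitor, a lower number a stronger inhibitor), compound 3 stands lowest of the three at 40 nM and is the strongest inhibitor here, with both gaps beyond the scatter. Compound 4 `O=C1C=CC2(C=C1)OCC(=O)N2c1nc(-c2cccc3ccccc23)nn1-c1ccccc1` awaits measurement. It carries hydrogen in place of methyl on an aromatic carbon so that 4-methylphenyl becomes phenyl. Among the measured compounds shown here, no measured pair isolates this change. Compound 1 also bears phenyl and gives 100 nM but differs from compound 4 by a further methyl on the core. No step beyond the scatter is expected, and any drift should be towards a higher number: the estimated change is a 1.8-fold higher number from compound 3 to compound 4 (0.24 log units; within the scatter) in all. For compound 4 the estimated value is 70 nM with an expected range from 30 nM to 160 nM in this assay.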

Compound 4, half-maximal inhibitory concentration: 50 nM
The estimate for compound 4 lay 1.4-fold (0.15 log units) above the measured number; measured number inside the range.
By their numbers in this assay, from the lowest: compounds 3, 4, 1 and 2 (each within the scatter of the next, the first and the last beyond it).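

In this assay, the step with hydrogen in place of methyl, turning 4-methylphenyl into phenyl, is a 1.3-fold higher number from compound 3 to compound 4 (0.10 log units; within the scatter) and so leaves the two compounds indistinguishable in this assay. The step with hydrogen in place of methyl on a saturated ring carbon, a 2.0-fold lower number from compound 1 to compound 4 (0.30 log units; within the scatter) and the step with naphthalen-1-yl in place of 2,3-dihydro-1,4-benzodioxin-6-yl, a 2.0-fold lower number from compound 2 to compound 4 (0.30 log units; within the scatter) also stay within the scatter. No measurement here bears on why these steps are small.

The compounds shown leave open whether a methoxy group, a fluorine atom or an amine at this aromatic carbon would move the number beyond the scatter.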